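Series notes: amine replacement at the triazine carbon

The source may hold more compounds than are shown below. What is called first, only, known or untested is meant among the compounds shown, and "the series" means these compounds.

Two compounds of the shared core have numbers in an assay on cell membranes for displacement of a labelled ligand from corticotropin-releasing factor receptor 1 (Rattus norvegicus); on this read-out higher numbers stand for weaker inhibition and lower numbers for stronger inhibition. Compound 1 `CCCN(CC1CC1)c1nc(C)nc2c(-c3ccc(OC)cc3C)c(C)nn12` gives 1.96 nM in this assay. Compound 2 `COc1cc(C)c(-c2c(C)nn3c(NC4CCC4)nc(C)nc23)c(OC)c1` gives 17.4 nM in this assay, the highest of the two numbers; the gap to compound 1 lies beyond the scatter, compound 1 being the stronger inhibitor of the pair. For the measured compounds named here, no single-point step between measured compounds is available.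

Compound 3 `CCC1CCCCN1c1nc(C)nc2c(-c3c(C)cc(OC)cc3OC)c(C)nn12` is not yet measured in this assay. It differs from compound 2 in one place: 2-ethylpiperidin-1-yl in place of cyclobutylamino on an aromatic carbon. The remaining part of the structure is unchanged.

For the step, a move to a lower number is expected; the estimated step of a 3.5-fold lower number from compound 2 to compound 3 (0.54 log units; beyond the scatter) is beyond the scatter but modest in size, since the only anchor for a substituent of this kind without a donor is compound 1, which in this assay gives 1.96 nM, and compound 3 keeps the dimethoxy aryl pattern of compound 2 rather than that of compound 1. For compound 3 the expected value in this assay is 5 nM, with a range of 1.5 nM to 18 nM.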

Compound 3, half-maximal inhibitory concentration: 3.26 nM
Compound 3: the middle estimate sits 1.5-fold (0.19 log units) above what was measured; the measured number falls inside the stated range.
By their numbers in this assay, from the lowest: compounds 1 and 3 (each within the scatter of the next); then compound 2.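

Within the shared core, the dimethoxy aryl pattern held constant, the exchange of cyclobutylamino for 2-ethylpiperidin-1-yl on the aromatic carbon between two ring nitrogen atoms gives, in this assay, a 5.3-fold lower number from compound 2 to compound 3 (0.73 log units; beyond the scatter). For the compounds shown here, this is the first single-change reading at this position, and it shows that the hydrogen-bond donor of cyclobutylamino is not needed for a low number here, since the entering group has none and still moves the value in the favourable direction, beyond the scatter. No measurement available bears on why the number falls.

The step changes several things at once, the donor, the ring size and the ethyl branch, so the compounds shown do not tell which of these accounts for it; plain piperidin-1-yl and N-methylcyclobutylamino would begin to separate them. Also open, going by these compounds, is whether a ring oxygen, as in morpholin-4-yl, is tolerated at this position, and whether the step holds with the aryl group of compound 1, which differs from compound 3 in more than one place and so cannot yet be compared with it.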